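The source may report more compounds than this note shows. Statements on the series, on what has been measured and on what is new or still open speak of the compounds shown alone.

Compound 2 `Fc1ccc(Nc2cc(Nc3ccc(Oc4ccncc4-c4cccnc4)c(F)c3)ncn2)cc1` and compound 1 `Fc1cc(Nc2cc(Nc3ccc(Cl)cc3)ncn2)ccc1Oc1ccncc1-c1cccnc1` share one core and differ only by chloro in place of fluoro on an aromatic carbon. In a functional assay on A549 cells (Homo sapiens) for cytotoxicity, read by MTT assay, with a stated time of 72 h (on this read-out higher numbers stand for weaker inhibition and lower numbers for stronger inhibition), compound 2 gives 710 nM, while compound 1 gives 1610 nM. Compound 3 `O=C(Nc1ccc(Oc2ccncc2-c2cccnc2)c(F)c1)c1nn(-c2ccc(F)cc2)c(=O)c2ccccc12` is built on another core; the difference between the two cores is not broken down here. In this assay compound 3 gives 820 nM. Compound 4 `O=C(Nc1ccc(Oc2ccncc2-c2cccnc2)c(F)c1)c1nn(-c2ccc(Cl)cc2)c(=O)c2ccccc12` has not yet been measured and differs from compound 3 by chloro in place of fluoro on an aromatic carbon, the same change as between compound 2 and compound 1. This change was seen once, as a 2.3-fold higher number from compound 2 to compound 1 (0.36 log units; beyond the scatter), and on that single example a step of similar size is expected in this assay for compound 4, namely a 2.0-fold higher number from compound 3 to compound 4 (0.29 log units; within the scatter). Compound 4 is therefore estimated at 1600 nM, expected to lie between 600 nM and 4000 nM.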

Compound 4, half-maximal inhibitory concentration: 1020 nM
Compound 4: middle estimate off by 1.6-fold (0.20 log units), on the high side; low and high end bracket the measured number.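

In this assay, putting chloro in place of fluoro on the core of compound 3 gives a 1.2-fold higher number from compound 3 to compound 4 (0.09 log units; within the scatter), a step too small to tell from the usual variation between repeat measurements. Set beside the earlier example, the two steps cannot be told apart: the same change on two cores in this assay, a 2.3-fold higher number (0.36 log units; beyond the scatter) from compound 2 to compound 1 and a 1.2-fold higher number (0.09 log units; within the scatter) from compound 3 to compound 4, 1.8-fold (0.26 log units) apart, within the scatter of two such steps This shows no sign that the two cores respond differently to the change, but two pairs, one of them a step within the scatter, do not prove that it carries over reliably across the series.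

From the compounds shown here alone, what a methoxy group, an amine or a carboxylic acid would do in place of the chloro, on either core, stays open.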